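The source may report more compounds than this note shows. Statements on the series, on what has been measured and on what is new or still open speak of the compounds shown alone.

Measured compounds:
compound 1 `COc1cccc(S(=O)(=O)Nc2ccc3oc(-c4ccccc4)nc3c2)c1` with > 63000 nM
compound 2 `CS(=O)(=O)Nc1ccc2oc(-c3ccccc3)nc2c1` with > 63000 nM

The series is followed in an assay on isolated protein for inhibition of malate dehydrogenase, mitochondrial (Sus scrofa), with stated times of 45 min and 30 min; on this read-out higher numbers stand for weaker inhibition and lower numbers for stronger inhibition. Compound 1 gives only a limit of the assay, > 63000 nM, and no number. Compound 2 likewise gives only a limit, > 63000 nM. The step that the two limits leave unreadable from compound 1 to compound 2, by methyl in place of 3-methoxyphenyl on a sulfonyl sulfur, is therefore of unreadable size, as the limit of > 63000 nM in this assay, at which 2 of the 2 values shown sit, shows; compound 2 stands at that limit with nothing further to place it.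

Compound 3 `CCc1ccc(S(=O)(=O)Nc2ccc3oc(-c4ccccc4)nc3c2)cc1` is not yet measured. It differs from compound 2 by 4-ethylphenyl in place of methyl on a sulfonyl sulfur. Within the data shown here, the only step that bears on it is the one from compound 1 to compound 2, which shows that an aromatic sulfonyl substituent and a methyl both sit at the limit, so no readable step in either direction is expected in this assay. Compound 3 is therefore expected to remain at the limit as well, an estimated step that the limit leaves unreadable from compound 2 to compound 3. The estimate for compound 3 is 100000 nM, ranging from 40000 nM to 300000 nM.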

Compound 3, half-maximal inhibitory concentration: > 63000 nM
Compound 3 was reported as a limit (the forecaster's own chance of this, stated with the estimate: 85%); the middle value does not contradict the limit.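

In this assay compound 3 gives > 63000 nM, which is a limit and not a number. Among these compounds, no step among compound 1, compound 2 and compound 3 can be read, as all three stand at the same limit: the limit of > 63000 nM in this assay, at which 3 of the 3 values shown sit. The compounds shown leave open whether any substituent on the sulfonyl sulfur gives a measurable value in this assay.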